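Aryl ketone swaps on the shared core: compound 4

The source may hold more compounds than are shown below. What is called first, only, known or untested is meant among the compounds shown, and "the series" means these compounds.

Measured so far in a functional assay on NCI/ADR-RES cells (Homo sapiens) for cytotoxicity, read by sulforhodamine B assay, with a stated time of 48 h, tested at 10 uM; on this read-out higher numbers stand for a weaker effect at the one concentration tested and lower numbers for a stronger effect:
compound 1 `COc1cc(-c2cc(/C=C/C(=O)c3ccc(Cl)c(Cl)c3)[nH]n2)cc(OC)c1OC` gives 51%
compound 2 `COc1ccc(C(=O)/C=C/c2cc(-c3cc(OC)c(OC)c(OC)c3)n[nH]2)cc1OC` gives 10%
compound 3 `COc1ccc(C(=O)/C=C/c2cc(-c3cc(OC)c(OC)c(OC)c3)n[nH]2)cc1` gives -1%

Compound 3 holds the lowest of the three numbers in this assay. Its nearest neighbour is compound 2, set off by a number 11 percentage points lower from compound 2 to compound 3 (beyond the scatter); the furthest is compound 1, set off by a number 52 percentage points lower from compound 1 to compound 3 (beyond the scatter).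

Compound 4 `COc1cc(-c2cc(/C=C/C(=O)c3ccc(F)c(F)c3)[nH]n2)cc(OC)c1OC` is not yet measured. Against compound 3 the change is 3,4-difluorophenyl in place of 4-methoxyphenyl on a carbonyl carbon.

For the measured compounds named here, two measured steps bear on this. Both replace the 3,4-dichlorophenyl on the carbonyl carbon of compound 1 with a methoxy-bearing phenyl: a number 41 percentage points lower from compound 1 to compound 2 (beyond the scatter) and a number 52 percentage points lower from compound 1 to compound 3 (beyond the scatter), both large. Compound 4 moves the other way, back to a halogenated phenyl, with fluorine rather than chlorine. As far as these compounds go, whether fluorine follows chlorine here is unknown from these three compounds, so the step is expected upward in this assay but of uncertain size, likely smaller than the reverse of the step from compound 1 to compound 3.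

For compound 4 the expected value in this assay is 28%, within 0% to 58%, which corresponds to an expected step of a number 29 percentage points higher from compound 3 to compound 4 (beyond the scatter).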

Compound 4, a percentage reported as activity, at one concentration (the size of the read-out at that concentration, not a potency): 11%
Compound 4: middle estimate off by 17 percentage points, on the high side, within the range that was stated.
By their numbers in this assay, from the lowest: compound 3; then compounds 2 and 4 (each within the scatter of the next); then compound 1.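

In this assay a halogenated phenyl on the carbonyl carbon does not by itself bring a high number: 3,4-difluorophenyl in place of 3,4-dichlorophenyl gives a number 40 percentage points lower from compound 1 to compound 4 (beyond the scatter) and so ranks as a large step, like those from compound 1 to the two methoxy-bearing compounds. Methoxy on this phenyl is therefore not needed for a low number, since 3,4-difluorophenyl in place of 3,4-dimethoxyphenyl gives a number 1 percentage points higher from compound 2 to compound 4 (within the scatter) and leaves these two groups indistinguishable at this position. Only 4-methoxyphenyl still separates from the difluoro group, with a number 12 percentage points higher from compound 3 to compound 4 (beyond the scatter) as a modest step, while among the four compounds the high number belongs to the 3,4-dichlorophenyl of compound 1 alone.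

Still open, as far as these compounds go, is how this carbonyl position responds to groups of another kind on the phenyl, such as a dimethylamino group, a nitrile or a carboxylic acid, and whether chlorine sets compound 1 apart only as a pair or also singly. Nothing available explains why chlorine and fluorine part ways here.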